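Hydroxamic acid in place of carboxylic acid on the amide

The compounds below may be only part of what the source reports. "The series", "measured", "known", "first", "only" and "open" are said of these compounds alone.

Compound 3 `CC(C)(CC(=O)O)NC(=O)c1ccc(CN(C(=O)Nc2ccc(OC(F)(F)F)cc2)C2CCC(C(C)(C)C)CC2)cc1` is one of three related compounds tested in an in vitro assay on BHK cells for inhibition of Glucagon receptor (Homo sapiens); a lower number here means a stronger inhibitor, a higher number a weaker inhibitor. In this assay compound 3 gives only a limit, > 10000 nM. Compound 1 `COCCCNC(=O)c1ccc(CN(C(=O)Nc2ccc(OC(F)(F)F)cc2)C2CCC(C(C)(C)C)CC2)cc1` likewise gives only a limit, > 10000 nM. Compound 2 `CC(C)(C)C1CCC(N(Cc2ccc(C(=O)NCCCC(=O)O)cc2)C(=O)Nc2ccc(OC(F)(F)F)cc2)CC1` also gives only a limit, > 10000 nM. The steps a step that the two limits leave unreadable from compound 1 to compound 2, a step that the two limits leave unreadable from compound 1 to compound 3 and a step that the two limits leave unreadable from compound 2 to compound 3 therefore cannot be sized; all three values rest at the limit of > 10000 nM in this assay, at which 3 of the 3 values shown sit. Compound 4 `CC(C)(C)C1CCC(N(Cc2ccc(C(=O)NCC(=O)NO)cc2)C(=O)Nc2ccc(OC(F)(F)F)cc2)CC1` differs from compound 3 by (hydroxycarbamoyl)methyl in place of 1-(carboxymethyl)-1-methylethyl on an amide-type nitrogen. Among the compounds with values here, no measured step can be sized, so none bears on this change. The account therefore expects compound 4 to stay at or near the limit, with a number no higher from compound 3 to compound 4 (the limit leaves the size open) not expected to exceed the scatter. Compound 4 is estimated at 10000 nM, within 3000 nM to 30000 nM.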

Compound 4, half-maximal inhibitory concentration: 2960 nM
Beside the measured number, compound 4's estimate is 3.4-fold (0.53 log units) above it; the whole stated range lies above it.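

In this assay, within the data shown here, (hydroxycarbamoyl)methyl on the amide-type nitrogen gives the first value that is a number and not a limit (an at least 3.3-fold lower number from compound 3 to compound 4 (0.52 log units; beyond the scatter)). The same gain appears against the chains of compound 2 (an at least 3.3-fold lower number from compound 2 to compound 4 (0.52 log units; beyond the scatter)) and compound 1 (an at least 3.3-fold lower number from compound 1 to compound 4 (0.52 log units; beyond the scatter)). Only one end of each step is a number, so the full size stays open: the limit of > 10000 nM in this assay, at which 3 of the 4 values shown sit.

The steps among compounds 1, 2 and 3 still cannot be read. Open too, from the compounds shown here alone, is whether the hydroxycarbamoyl end or the chain length matters, which a longer chain ending in hydroxycarbamoyl would test.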